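Trifluoromethyl for methyl on the core: an expectation

The source may hold more compounds than are shown below. What is called first, only, known or untested is meant among the compounds shown, and "the series" means these compounds.

compound 1 `CN(C(=O)NC(=O)c1ccc(C(F)(F)F)cc1)c1nc(C(F)(F)F)c(C(=O)N/N=C/c2ccc(C(F)(F)F)cc2)s1`: > 100 ug/mL
compound 2 `CNc1nc(C)c(C(=O)N/N=C/c2cccc(C(F)(F)F)c2)s1`: > 100 ug/mL
compound 3 `CNc1nc(C)c(C(=O)N/N=C/c2cc(C(F)(F)F)cc(C(F)(F)F)c2)s1`: > 100 ug/mL

All three measured compounds were tested in a functional assay on MCF7 cells (Homo sapiens) for inhibition, read by MTT assay, with a stated time of 72 h; on this read-out lower numbers stand for stronger inhibition and higher numbers for weaker inhibition. In this assay compound 1 gives > 100 ug/mL, which is a limit of the assay rather than a number. Compound 2 gives > 100 ug/mL, again a limit. Compound 3 gives > 100 ug/mL, also a limit. Compound 3 therefore stands at the same limit as the other two values shown, as the limit of > 100 ug/mL in this assay, at which 3 of the 3 values shown sit, records; none of the three is a measured number. Going by the values given here, the only single-point step among them, a step that the two limits leave unreadable from compound 2 to compound 3, cannot be read because both of its ends are limits.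

Compound 4 `CNc1nc(C(F)(F)F)c(C(=O)N/N=C/c2cc(C(F)(F)F)cc(C(F)(F)F)c2)s1` differs from compound 3 by trifluoromethyl in place of methyl on an aromatic carbon. Among the compounds with values here, no measured step matches this change, so the measured steps give no guide to its size or direction. Compound 1 already carries a trifluoromethyl on an aromatic carbon of a five-membered aromatic ring with 1 nitrogen and 1 sulfur, and in this assay compound 1 shows only a limit. With every value shown sitting at the limit, the step expected for compound 4 is a step that the limit leaves unreadable from compound 3 to compound 4, meaning no change the numbers can resolve. Compound 4 is therefore estimated at 120 ug/mL, with a range from 60 ug/mL to 300 ug/mL, and the assay is expected most likely to report only a limit again.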

Compound 4, half-maximal inhibitory concentration: > 100 ug/mL
Compound 4 ended at the assay's limit; the forecaster's own chance of this, stated with the estimate: 85%; the middle value lies beyond the limit too.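

Compound 3 and compound 4 both stop at a limit rather than a number in this assay, so no step can be read from swapping methyl for trifluoromethyl between them: the limit of > 100 ug/mL in this assay, at which 4 of the 4 values shown sit. The compounds shown leave open whether any of them inhibits these cells at all, and whether this swap on the core changes that.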